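Phenyl for bromo on the acylguanidine core

The source may report more compounds than this note shows. Statements on the series, on what has been measured and on what is new or still open speak of the compounds shown alone.

Compound 1, `Cc1cc(Br)c(S(C)(=O)=O)cc1C(=O)N=C(N)N`, is the reference point of this small set. In a functional assay for inhibition of sodium/hydrogen exchanger (Oryctolagus cuniculus) (a lower number here means a stronger inhibitor, a higher number a weaker inhibitor), compound 1 gives 12 nM, the lowest of the three numbers available. Its nearest neighbour is compound 3, `Cc1ccc(-c2ccc(C(=O)N=C(N)N)cc2S(C)(=O)=O)cc1`, which in this assay gives 100 nM; compound 3 differs from compound 1 in more than one place, so only the two values themselves can be compared. For the measured compounds named here, the furthest is compound 2, `CCN(CC)Cc1cc(Br)c(S(C)(=O)=O)cc1C(=O)N=C(N)N`, which in this assay gives 9500 nM; the single measured step, a 790-fold higher number from compound 1 to compound 2 (2.90 log units; beyond the scatter), concerns a different part of the molecule from the change considered here and so bears on it only loosely.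

Compound 4, `Cc1cc(-c2ccccc2)c(S(C)(=O)=O)cc1C(=O)N=C(N)N`, differs from compound 1 as follows: phenyl in place of bromo on an aromatic carbon. Going by the values given here, no measured step covers this exchange directly. The closest guide is compound 3, which carries an aromatic ring at the same kind of position and gives a higher number than compound 1. A moderate weakening is therefore expected: compound 4 is estimated at 60 nM in this assay, within 15 nM to 250 nM, a step of a 5.0-fold higher number from compound 1 to compound 4 (0.70 log units; beyond the scatter).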

Compound 4, half-maximal inhibitory concentration: 19 nM
For compound 4 the middle estimate is 3.2-fold (0.50 log units) above the measured one, within the range that was stated.
By their numbers in this assay, from the lowest: compounds 1 and 4 (each within the scatter of the next); then compound 3; then compound 2.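

In this assay the exchange gives a 1.6-fold higher number from compound 1 to compound 4 (0.20 log units; within the scatter), so on this aromatic carbon, ortho to a methylsulfonyl group, a phenyl group of 6 heavy atoms and a single bromine cannot be told apart. The position therefore accepts an added six-membered aromatic ring with no step beyond the scatter, whereas the diethylamino group on the saturated chain carbon, a different place on the core, gives a 790-fold higher number from compound 1 to compound 2 (2.90 log units; beyond the scatter). Nothing measured here explains why bromo and phenyl read alike.

From the compounds shown here alone, this rests on one pair, so it remains open whether the result extends to a phenyl ring carrying a carboxylic acid or an amine. Going by these compounds, it is equally open how a saturated alkyl chain or a morpholine ring on the same aromatic carbon would read.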